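Removing one methoxy from a trimethoxy aryl on a pyrazole chalcone

This account rests on a few compounds, and the source may have more. Where it says the series, first, only, none or still open, it means among the compounds named here.

Compound 1, `COc1ccc(-c2cc(/C=C/C(=O)c3ccc(N)cc3)[nH]n2)cc1`, gives 4010 nM in a functional assay on SK-MEL-28 cells (Homo sapiens) for inhibition, read by sulforhodamine B assay, with a stated time of 48 h; a lower number here means a stronger inhibitor of growth, a higher number a weaker inhibitor of growth.
Compound 2, `COc1cc(-c2cc(/C=C/C(=O)c3ccc(N)cc3)[nH]n2)cc(OC)c1OC`, gives 4080 nM in this assay.

These two values are the only ones in hand. Compound 2 holds the higher of the two numbers, yet compound 1 sits so close to it that the gap lies within the scatter, so nothing can be said about an order between them. For the measured compounds named here, no step between measured compounds that differ in a single place is available, so there is no measured step to lean on.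

Compound 3, `COc1ccc(-c2cc(/C=C/C(=O)c3ccc(N)cc3)[nH]n2)cc1OC`, has not yet been tested. It differs from compound 2 by hydrogen in place of methoxy on an aromatic carbon. With compound 1 and compound 2 showing practically the same number despite carrying different numbers of methoxy groups, the expectation is that the step from compound 2 to compound 3 in this assay stays within the scatter, in no particular direction, estimated at a 1.0-fold lower number from compound 2 to compound 3 (0.01 log units; within the scatter). Compound 3 is therefore expected to give about 4000 nM, with a likely range from 1800 nM to 9000 nM.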

Compound 3, concentration for total growth inhibition: 5660 nM
Compound 3: the middle estimate sits 1.4-fold (0.15 log units) below what was measured; the measured number falls inside the stated range.
By their numbers in this assay, from the lowest: compounds 1, 2 and 3 (each within the scatter of the next).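

In this assay, the step of a 1.4-fold higher number from compound 2 to compound 3 (0.14 log units; within the scatter) removes the methoxy ortho to a methoxy group and meta to a large group, and the step of a 1.4-fold higher number from compound 1 to compound 3 (0.15 log units; within the scatter) puts a methoxy back on that kind of carbon. This gives the change its first direct reading, from both sides, and both steps stay within the scatter, so neither taking this methoxy away nor adding it separates the compounds. Across compound 1, compound 2 and compound 3, an aryl carrying one, two or three methoxy groups therefore shows no order in this assay, and no measurement in hand gives a reason for that.

Going by these compounds, what remains open is whether this carbon tolerates other groups equally well, since only hydrogen and methoxy are compared there, and a hydroxyl, a fluorine or an amine could behave differently. On these data alone, it is also open whether the flat response would hold on an aryl with no methoxy at all, or with a longer chain such as ethoxy in place of methoxy.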